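Swapping nitrobenzyl for dichlorobenzyl in a cyclic sulfonamide

The source may report more compounds than this note shows. Statements on the series, on what has been measured and on what is new or still open speak of the compounds shown alone.

Compound 1 `O=C1c2ccccc2N(Cc2ccc([N+](=O)[O-])cc2)S(=O)(=O)N1Cc1ccc([N+](=O)[O-])cc1`: 53000 nM
Compound 2 `O=C1c2ccccc2N(Cc2ccc([N+](=O)[O-])cc2)S(=O)(=O)N1Cc1ccccc1`: > 59000 nM
Compound 3 `O=S1(=O)N=C(OCc2ccc(Cl)c(Cl)c2)c2ccccc2N1Cc1ccc(Cl)c(Cl)c1`: 48000 nM

In a functional assay on MRC5 cells (Homo sapiens) (on this read-out higher numbers stand for lower toxicity in this test and lower numbers for higher toxicity in this test), compound 1 gives 53000 nM and compound 3 gives 48000 nM. For compound 2 the assay reports only a limit, > 59000 nM, not a number. Compound 2 thus stands at the limit of > 59000 nM in this assay, at which 1 of the 3 values shown sits, the upper edge of the numbers shown. Compound 4 `O=C1c2ccccc2N(Cc2ccc(Cl)c(Cl)c2)S(=O)(=O)N1Cc1ccccc1` differs from compound 2 by 3,4-dichlorophenyl in place of 4-nitrophenyl on a saturated chain carbon bound to a sulfonamide nitrogen in a ring. For the measured compounds named here, the one measured step, an at least 1.1-fold higher number from compound 1 to compound 2 (0.04 log units; that floor lies within the scatter), does not touch this change and lies within the scatter. Compound 3, which carries 3,4-dichlorobenzyl groups, gives 48000 nM, close to compound 1. For this assay the expected step of an at least 1.0-fold lower number from compound 2 to compound 4 (0.03 log units; that floor lies within the scatter) is therefore none beyond the scatter. Compound 4 is expected near 55000 nM, between 30000 nM and 100000 nM.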

Compound 4, half-maximal cytotoxic concentration: 56000 nM
Estimate against measurement, compound 4: 1.0-fold (0.01 log units) below; the measured number falls inside the stated range.
By their numbers in this assay, from the lowest: compounds 3, 1 and 4 (each within the scatter of the next). At a limit, above all of these: compound 2.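

In this assay, for the compounds shown here, this is the first change read on a saturated chain carbon bound to a sulfonamide nitrogen in a ring, and replacing 4-nitrobenzyl with 3,4-dichlorobenzyl gives an at least 1.0-fold lower number from compound 2 to compound 4 (0.02 log units; that floor lies within the scatter). That step is only a floor, and it shows no shift beyond the scatter. Compound 2 has a limit and not a number: the limit of > 59000 nM in this assay, at which 1 of the 4 values shown sits.

Going by these compounds, the true distance from compound 2 to compound 4 stays open. So does the outcome of placing an amine or a carboxylic acid on the benzyl group here.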